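This account rests on a few compounds, and the source may have more. Where it says the series, first, only, none or still open, it means among the compounds named here.

Measured compounds in a functional assay on K562 cells (Homo sapiens) for antiproliferative activity, read by MTT assay, with a stated time of 48 h; a lower number here means a stronger inhibitor, a higher number a weaker inhibitor:
compound 1, `CN(C)CCCCn1c(N)c(-c2nc3ccccc3o2)c2nc(C#N)c(C#N)nc21`, gives 1380 nM.
compound 2, `CCN(CC)CCCCn1c(N)c(-c2nc3ccccc3o2)c2nc(C#N)c(C#N)nc21`, gives 1980 nM.
compound 3, `CN(C)CCn1c(N)c(-c2nc3cc(Cl)ccc3[nH]2)c2nc(C#N)c(C#N)nc21`, gives 11300 nM.

Compound 4, `CCN(CC)CCn1c(N)c(-c2nc3cc(Cl)ccc3[nH]2)c2nc(C#N)c(C#N)nc21`, has not yet been measured in this assay. The difference between the core of compound 1 and the core of compound 3 is not broken down here; their two values show compound 3 with the higher number. Compound 2 differs from compound 1 by diethylamino in place of dimethylamino on a saturated chain carbon, four bonds along the chain from an aromatic nitrogen, and that change gave a 1.4-fold higher number from compound 1 to compound 2 (0.16 log units; within the scatter). Compound 4 differs from compound 3 by diethylamino in place of dimethylamino on a saturated chain carbon, two bonds along the chain from an aromatic nitrogen; the place is not the same, two bonds along the chain from an aromatic nitrogen rather than four, so this is the same kind of change, not the same change. For compound 4 the expected step is a 1.3-fold higher number from compound 3 to compound 4 (0.12 log units; within the scatter), resting on a 1.4-fold higher number from compound 1 to compound 2 (0.16 log units; within the scatter). Compound 4 is estimated at 15000 nM, likely within 7500 nM to 30000 nM.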

Compound 4, half-maximal inhibitory concentration: > 50000 nM
Compound 4 gave a limit, no number; the forecaster's own chance of this, stated with the estimate: 10%; middle value at least 3.3-fold (0.52 log units) away from the limit.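

In this assay compound 4 gives > 50000 nM, a limit of the assay and not a number: the limit of > 50000 nM in this assay, at which 1 of the 4 values shown sits.

Diethylamino in place of dimethylamino gave an at least 4.4-fold higher number from compound 3 to compound 4 (0.64 log units; beyond the scatter), and the change did not carry over between the two cores at one size: the same change on two cores in this assay, a 1.4-fold higher number (0.16 log units; within the scatter) from compound 1 to compound 2 and an at least 4.4-fold higher number (0.64 log units; beyond the scatter) from compound 3 to compound 4, at least 3.0-fold (0.48 log units) apart, beyond the scatter of two such steps

On these data alone, this does not show whether the core or the chain sets that gap, since the change sits two bonds along the chain from an aromatic nitrogen in one pair and four bonds in the other, and the full size of the step stays unknown behind the limit.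

The compounds shown leave open how 2-(diethylamino)ethyl behaves on the core of compound 1. They also leave open how a primary amine or a longer chain behaves on the core of compound 3.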